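A few compounds are considered here, and "the series" means these few. Any claim that something is new, unique, unknown or untested is made for them only; others in the source may bear on it.

Measured compounds:
compound 1, `CC/N=C(/NC#N)NCCCCn1nc(-c2ccccc2)ccc1=O` — 92 mg/kg in a functional assay on the whole organism (stomach) with Rattus norvegicus as the target; on this read-out higher numbers stand for an effect only at larger amounts of compound and lower numbers for an effect already at smaller amounts
compound 2, `N/C(S)=N/CCCCn1nc(-c2ccccc2)ccc1=O` — 36.3 mg/kg in this assay

Compound 1 stands at the highest of the two numbers; its nearest neighbour is compound 2, reached by a 2.5-fold lower number from compound 1 to compound 2 (0.40 log units; beyond the scatter). Compound 3, `O=c1ccc(-c2ccccc2)nn1CCCCNC(=S)Nc1ccccc1`, is not yet measured. It differs from compound 1 by a group of 9 heavy atoms (7 carbon, 1 nitrogen, 1 sulfur; one six-membered aromatic ring of carbon only) in place of a group of 7 heavy atoms (4 carbon, 3 nitrogen; no ring), on an amine nitrogen. Going by the values given here, the one measured step that bears on this change is the one from compound 1 to compound 2, where the cyanoguanidine gave way to a thiourea and the dose fell by a modest amount beyond the scatter. Among the compounds with values here, compound 3 also carries a thiourea, though one bearing a phenyl ring rather than a bare amine, so the only guidance points downward. A modest lowering, a 1.8-fold lower number from compound 1 to compound 3 (0.26 log units; within the scatter), is therefore expected, with real uncertainty about the effect of the added ring. The dose for compound 3 is estimated at 50 mg/kg, within a range from 22 mg/kg to 115 mg/kg.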

Compound 3, dose for half-maximal effect: > 100 mg/kg
Compound 3 gave a limit, no number (the forecaster's own chance of this, stated with the estimate: 5%); middle value at least 2.0-fold (0.30 log units) away from the limit.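

For compound 3, this assay gives only a limit of the assay, not a number: the limit of > 100 mg/kg in this assay, at which 1 of the 3 values shown sits.

The step reads an at least 1.0-fold higher number from compound 1 to compound 3 (0.03 log units; that floor lies within the scatter), so this phenyl-bearing thiourea on the amine nitrogen shows no gain over the cyanoguanidine group of compound 1, although the floor of that step lies too close to separate the two. A thiourea as such is therefore not enough for a low dose like that of compound 2 at 36.3 mg/kg, since compound 3 carries a thiourea too, with an aromatic ring added to it.

On these data alone, how far the true dose of compound 3 lies past its limit remains unknown. Also open, as far as these compounds go, is where a thiourea carrying a methyl or an ethyl group in place of the phenyl ring would fall in this assay.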